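Swapping the aryl group on the aromatic nitrogen

A few compounds are considered here, and "the series" means these few. Any claim that something is new, unique, unknown or untested is made for them only; others in the source may bear on it.

Compound 2 `C=CC(=O)Nc1cc(Nc2ncc3ncn(-c4ccccc4Br)c3n2)c(OC)cc1N(C)CCN(C)C` stands highest of the two numbers recorded, though only within the scatter of compound 1 `C=CC(=O)Nc1cc(Nc2ncc3ncn(-c4ccc(I)cc4)c3n2)c(OC)cc1N(C)CCN(C)C`: in an ADME assay on HT-29 cells (Homo sapiens) for cytotoxicity, read by MTT assay, with a stated time of 72 h (on this read-out higher numbers stand for weaker inhibition and lower numbers for stronger inhibition), compound 2 gives 16200 nM, and compound 1 gives 9520 nM. Compound 3 `C=CC(=O)Nc1cc(Nc2ncc3ncn(-c4ccc(F)c(Cl)c4)c3n2)c(OC)cc1N(C)CCN(C)C` differs from compound 2 in one place: 3-chloro-4-fluorophenyl in place of 2-bromophenyl on an aromatic nitrogen. Going by the values given here, the only measured step that bears on this change is a 1.7-fold higher number from compound 1 to compound 2 (0.23 log units; within the scatter), which likewise exchanged the group on the aromatic nitrogen and stayed within the scatter. On that basis the step of a 1.4-fold lower number from compound 2 to compound 3 (0.13 log units; within the scatter) is expected to stay within the scatter as well. The estimate for compound 3 is 12000 nM, with a range from 4000 nM to 36000 nM.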

Compound 3, half-maximal inhibitory concentration: 1610 nM
Beside the measured number, compound 3's estimate is 7.5-fold (0.87 log units) above it, and the stated range ends above it.
By their numbers in this assay, from the lowest: compound 3; then compounds 1 and 2 (each within the scatter of the next).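

In this assay the group on this aromatic nitrogen proves able to shift the number: a 10-fold lower number from compound 2 to compound 3 (1.00 log units; beyond the scatter), and a 5.9-fold lower number from compound 1 to compound 3 (0.77 log units; beyond the scatter), whereas the earlier exchange of one halogenated phenyl for another stayed within the scatter. Compound 3, carrying 3-chloro-4-fluorophenyl, therefore stands lowest of the three. No evidence is available here to account for this difference.

The compounds shown leave open whether 3-chlorophenyl or 4-fluorophenyl alone would give the same result. They also leave open how a phenyl bearing an amine or a carboxylic acid would behave here.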